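This account rests on a few compounds, and the source may have more. Where it says the series, first, only, none or still open, it means among the compounds named here.

Measured so far in an assay on cell membranes for displacement of a labelled ligand from Neuronal acetylcholine receptor; alpha4/beta2 (Rattus norvegicus); a higher number here means a weaker inhibitor, a lower number a stronger inhibitor:
compound 1 `Cc1ccc(Nc2cncc(N3CC4CC(C3)N4)c2)cc1` gives 0.148 nM
compound 2 `Clc1cccc(Nc2ccc(N3CC4CC(C3)N4)cn2)c1` gives 2.2 nM
compound 3 `Clc1cccc(Nc2cncc(N3CC4CC(C3)N4)c2)c1` gives 0.124 nM

Compound 3 and compound 1 share one core and differ only by 4-methylphenyl in place of 3-chlorophenyl on a nitrogen on an aromatic ring; that change gave a 1.2-fold higher number from compound 3 to compound 1 (0.08 log units; within the scatter), so the two values tell no difference apart. Compound 2 is built from the same atoms as compound 3, joined differently; the difference between the two cores is not broken down here. In this assay compound 2 stands well apart from compound 1 and compound 3, beyond the scatter.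

Compound 4 `Cc1ccc(Nc2ccc(N3CC4CC(C3)N4)cn2)cc1` has not been measured. It differs from compound 2 by 4-methylphenyl in place of 3-chlorophenyl on a nitrogen on an aromatic ring, the same change as from compound 3 to compound 1. The expectation for compound 2 to compound 4 is a 1.2-fold higher number from compound 2 to compound 4 (0.07 log units; within the scatter), because the earlier step of a 1.2-fold higher number from compound 3 to compound 1 (0.08 log units; within the scatter) stayed within the scatter. Compound 4 is therefore estimated at 2.6 nM, expected between 1.2 nM and 6 nM.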

Compound 4, inhibition constant: 52.1 nM
For compound 4 the middle estimate is 20-fold (1.30 log units) below the measured one; the measured number lies above the stated range.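

In this assay, putting 4-methylphenyl in place of 3-chlorophenyl gives a 24-fold higher number from compound 2 to compound 4 (1.37 log units; beyond the scatter) and so shows that this change does not carry over unaltered from one core to the other: the same change on two cores in this assay, a 1.2-fold higher number (0.08 log units; within the scatter) from compound 3 to compound 1 and a 24-fold higher number (1.37 log units; beyond the scatter) from compound 2 to compound 4, 20-fold (1.30 log units) apart, beyond the scatter of two such steps. The same swap leaves the number within the scatter on one core and makes it much higher on the other, so the result of the change depends on the core that carries it. These four compounds do not show why the two cores differ, and they give no rule for any third core.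

Going by these compounds, how other groups in the same place would behave on these two cores remains open, for example a plain phenyl or a phenyl carrying an amine or a carboxylic acid. Whether such groups would also separate the two cores is equally unknown.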